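Working notes: from compound 3 to compound 4

A few compounds are considered here, and "the series" means these few. Any claim that something is new, unique, unknown or untested is made for them only; others in the source may bear on it.

Measured in a functional assay, read by spectrophotometry, tested at 100 uM; a lower number here means a stronger inhibitor, a higher number a weaker inhibitor:
- compound 1 `O=C(/C=C/c1ccccc1)c1cccc(NC(=O)c2cc(-c3ccncc3)n[nH]2)c1`: 67100 nM
- compound 2 `O=C(/C=C/c1cccs1)c1cccc(NC(=O)c2cc(-c3ccncc3)n[nH]2)c1`: 27600 nM
- compound 3 `O=C(/C=C/c1ccc([N+](=O)[O-])cc1)c1cccc(NC(=O)c2cc(-c3ccncc3)n[nH]2)c1`: 52800 nM

Compound 3 cannot be separated from the other two compounds, as the data show a 1.3-fold lower number from compound 1 to compound 3 (0.10 log units; within the scatter) and a 1.9-fold higher number from compound 2 to compound 3 (0.28 log units; within the scatter). The unmeasured compound 4 `O=C(/C=C/c1ccc(Cl)cc1Cl)c1cccc(NC(=O)c2cc(-c3ccncc3)n[nH]2)c1` differs from it at one place, with 2,4-dichlorophenyl in place of 4-nitrophenyl on a double-bonded chain carbon bound to a double-bonded chain carbon.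

Among the compounds with values here, no measured compound carries chlorine, so the series offers no direct precedent for this group. The measured changes at this place are the two steps above and a 2.4-fold lower number from compound 1 to compound 2 (0.39 log units; beyond the scatter), the only one beyond the scatter, and it is modest. On that basis, no step beyond the scatter is expected in this assay, and no direction is favoured. The estimate amounts to a 1.2-fold lower number from compound 3 to compound 4 (0.07 log units; within the scatter), an expected step that carries no weight as a direction. For compound 4 the expected value is 45000 nM, with an estimated range of 18000 nM to 95000 nM.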

Compound 4, half-maximal inhibitory concentration: 35000 nM
The estimate for compound 4 lay 1.3-fold (0.11 log units) above the measured number, within the range that was stated.
By their numbers in this assay, from the lowest: compounds 2, 4, 3 and 1 (each within the scatter of the next, the first and the last beyond it).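

In this assay, a chlorine-bearing group at this place, on a double-bonded chain carbon bound to a double-bonded chain carbon, cannot be separated from any of the earlier groups: the data give a 1.5-fold lower number from compound 3 to compound 4 (0.18 log units; within the scatter), a 1.3-fold higher number from compound 2 to compound 4 (0.10 log units; within the scatter) and a 1.9-fold lower number from compound 1 to compound 4 (0.28 log units; within the scatter). Within the data shown here, compound 4 thus lies within the scatter of both compound 1 and compound 2, the only pair here separated by more than the scatter, at a 2.4-fold lower number from compound 1 to compound 2 (0.39 log units; beyond the scatter), so it adds a new group at this place without widening the spread of the series. Nothing available accounts for this result.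

Among these compounds, every group at this place so far is a ring group, so the effect of an amine, a carboxylic acid or a longer alkyl chain there remains open. Also open is whether the double-bonded chain, unchanged across all the compounds shown, matters to inhibition.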